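Replacing Ethyl With a Carbonyl-Bearing Group on the Ring Nitrogen

This account rests on a few compounds, and the source may have more. Where it says the series, first, only, none or still open, it means among the compounds named here.

Compound 1 `O=C1NCCc2nc(C#Cc3ccccc3F)sc21` gives 1500 nM in an assay on HEK293 cells for positive allosteric modulation of metabotropic glutamate receptor 5 (Homo sapiens), read by FLIPR, with a stated time of 1 h; a higher number here means that more compound is needed for the effect, a lower number that less compound is needed.
Compound 2 `CCN1CCc2nc(C#Cc3ccccc3)sc2C1` gives only the limit > 10000 nM in this assay, not a number.
Compound 3 `Fc1cccc(C#Cc2nc3c(s2)CN(C2CCC2)CC3)c1` likewise gives only the limit > 10000 nM in this assay.

Compound 2 therefore stands at the edge of what this assay can report, and it is not alone there: the limit of > 10000 nM in this assay, at which 2 of the 3 values shown sit. Only compound 1 yields a measured number, so no comparison between two numbers is available, and no single change between measured compounds has been quantified.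

Compound 4 `COC1CC(C(=O)N2CCc3nc(C#Cc4ccccc4)sc3C2)C1` is the next compound to be tested. It differs from compound 2 in one place: (3-methoxycyclobutyl)carbonyl in place of ethyl on an amine nitrogen in a ring. Compound 2 and compound 4 thus share the same core and the same phenyl-alkyne arm; only the substituent on the ring nitrogen changes.

With compound 2 at a limit, the step to compound 4 can only be an expectation. Among the measured compounds shown here, compound 1, the one compound that does return a number, 1500 nM, also contains a carbonyl, and compound 4 brings a carbonyl into the molecule as well. On that slender basis a step from compound 2 to compound 4 toward less compound needed is expected, an at least 4.0-fold lower number from compound 2 to compound 4 (0.60 log units; beyond the scatter), though the chance remains that compound 4 too reports only a limit. The estimate for compound 4 in this assay is 2500 nM, expected to fall between 500 nM and 12000 nM.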

Compound 4, half-maximal effective concentration: 640 nM
Compound 4: the middle estimate sits 3.9-fold (0.59 log units) above what was measured, within the range that was stated.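

Among the compounds shown here, the first two compounds with a group on this ring nitrogen, compound 2 and compound 3, offered only limits, so they could not show whether this position can support activity at all. In this assay, placing (3-methoxycyclobutyl)carbonyl in place of ethyl on this amine nitrogen in a ring gives an at least 15-fold lower number from compound 2 to compound 4 (1.19 log units; beyond the scatter), a large step that lies beyond the scatter, and so shows that what sits on this nitrogen can strongly change the read-out while the shared core and the phenyl-alkyne arm stay the same. The full size of the step remains unknown because the starting point, compound 2, is a limit of the assay rather than a number: the limit of > 10000 nM in this assay, at which 2 of the 4 values shown sit.

The change brings in a carbonyl, a four-membered ring and a methoxy group all at once, so the compounds shown do not tell which of these parts carries the step. Open too, as far as these compounds go, is how simpler or different groups on the same nitrogen would read in this assay, such as a plain acetyl, a carbonyl-bearing longer chain, or a carbonyl group carrying an amine.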